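A 3-chloro-2-fluorophenyl in place of phenyl

The source may hold more compounds than are shown below. What is called first, only, known or untested is meant among the compounds shown, and "the series" means these compounds.

In an ADME assay on a cell-free system (plasma, Mus musculus) for protein binding, compound 1 (`CNc1[nH]c(=O)n(O)c(=O)c1C(=O)NCc1ccccc1`) stands at 70.9% and compound 2 (`CCNc1[nH]c(=O)n(O)c(=O)c1C(=O)NCc1ccccc1`) at 83.9% on the same measure. Within the data shown here, the only measured step, methyl in place of hydrogen on a saturated chain carbon bound to a nitrogen on an aromatic ring, is a 1.8-fold lower unbound fraction from compound 1 to compound 2 (0.26 log units; within the scatter) and so leaves compound 2 level with compound 1. Compound 3 (`CCNc1[nH]c(=O)n(O)c(=O)c1C(=O)NCc1cccc(Cl)c1F`) carries 3-chloro-2-fluorophenyl in place of phenyl on a saturated chain carbon bound to an amide-type nitrogen. Among the measured compounds shown here, no measured step touches that place, so the step to compound 2 serves only as a weak guide. On that guide, a similar or somewhat larger shift toward less free compound is expected in this assay (a 2.0-fold lower unbound fraction from compound 2 to compound 3 (0.30 log units; within the scatter)). For compound 3 the estimate is 92% with an expected range from 85% to 97% in this measure.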

Compound 3, plasma protein binding in the Mus musculus assay: 94%
Beside the measured number, compound 3's estimate is 1.3-fold (0.12 log units) (unbound fraction) above it, within the range that was stated.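

At the place on a saturated chain carbon bound to an amide-type nitrogen, the change to 3-chloro-2-fluorophenyl gives in the Mus musculus assay a 2.7-fold lower unbound fraction from compound 2 to compound 3 (0.43 log units; beyond the scatter), a modest shift and the only step shown that lies beyond the scatter, since the earlier change on the chain stayed within it. In a physicochemical assay for pharmacokinetics (a higher number here means that the compound lasts longer, a lower number that the compound disappears faster), compound 2 gives > 24 h, which is a limit of the assay and not a number. In the physicochemical assay compound 3 gives > 24 h, which is likewise a limit.

From the compounds shown here alone, the half-life step between these two compounds therefore cannot be read, because both sit at the same limit: the limit of > 24 h in the physicochemical assay, at which 2 of the 2 values shown sit. It also stays open whether the chlorine or the fluorine carries the shift in protein binding, and how an amine or a carboxylic acid on the phenyl would compare.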